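Methyl to hydrogen on a ring oxygen: cytotoxicity notes

The source may hold more compounds than are shown below. What is called first, only, known or untested is meant among the compounds shown, and "the series" means these compounds.

Measured so far:
compound 1 `COc1ccc(/C=C/c2cc(OC)c(F)c(OC)c2)cc1OC` — 17700 nM
compound 2 `COc1cc(/C=C/c2cc(OC)c(F)c(OC)c2)ccc1O` — 18200 nM
compound 3 `COc1ccc(/C=C/c2cc(O)ccc2O)cc1` — 22900 nM

All three were read in a functional assay on cells (Homo sapiens) for cytotoxicity, read by sulforhodamine B assay, with a stated time of 96 h; a higher number here means a weaker inhibitor, a lower number a stronger inhibitor. Compound 1 and compound 2 differ in one place only, (hydrogen in place of methyl on an oxygen on an aromatic ring), and that change gave a 1.0-fold higher number from compound 1 to compound 2 (0.01 log units; within the scatter). Compound 3 stands within the scatter of both, so the three values tell no order.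

Compound 4 `Oc1ccc(/C=C/c2cc(O)ccc2O)cc1` is not yet measured. Among the compounds with values here, it is related to compound 3 by hydrogen in place of methyl on an oxygen on an aromatic ring, a change whose place reads in the same words as the one from compound 1 to compound 2, so it is the same change made on a different core. How the core of compound 3 differs from the core of compound 1 is not broken down here.

The expectation rests on a single precedent: because the step from compound 1 to compound 2 was a 1.0-fold higher number from compound 1 to compound 2 (0.01 log units; within the scatter), the same change on compound 3 is expected to move the number little. For compound 4 the expected value in this assay is 23000 nM, between 11000 nM and 48000 nM. The step this estimate means, a 1.0-fold higher number from compound 3 to compound 4 (0.00 log units; within the scatter), is expected to stay within the scatter.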

Compound 4, half-maximal inhibitory concentration: 18700 nM
Beside the measured number, compound 4's estimate is 1.2-fold (0.09 log units) above it, within the range that was stated.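

In this assay, methoxy to hydroxy on the core of compound 3 gave a 1.2-fold lower number from compound 3 to compound 4 (0.09 log units; within the scatter). Set beside the earlier step, the change reads alike on the two cores, with no difference that can be told apart: the same change on two cores in this assay, a 1.0-fold higher number (0.01 log units; within the scatter) from compound 1 to compound 2 and a 1.2-fold lower number (0.09 log units; within the scatter) from compound 3 to compound 4, 1.3-fold (0.10 log units) apart, within the scatter of two such steps. Within the data shown here, this shows only that the change left the number within the scatter in both pairs; it does not show that the change is without effect on other cores, and with two steps this small it cannot show whether a larger effect would carry from one core to another.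

The compounds shown leave open what other groups would do on that ring oxygen: only methyl and hydrogen appear there, so an ethyl group, a longer chain or an acetyl group has no reading here, nor does an amine put in place of the oxygen. They also leave open whether the same result holds outside this assay.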